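Methoxy for methylamino on the iodo compound

The compounds below may be only part of what the source reports. "The series", "measured", "known", "first", "only" and "open" are said of these compounds alone.

Compound 1 `COc1ncnc2c1c(-c1cccs1)cn2[C@@H]1O[C@H](CO)[C@@H](O)[C@H]1O`: 70 nM
Compound 2 `CNc1ncnc2c1c(I)cn2[C@@H]1O[C@H](CO)[C@@H](O)[C@H]1O`: > 100000 nM

Within the data shown here, two measured compounds so far in a functional assay on K562 cells (Homo sapiens), read by MTT assay, with a stated time of 72 h; on this read-out lower numbers stand for stronger inhibition and higher numbers for weaker inhibition. Compound 1 gives 70 nM in this assay. For compound 2 this assay gives only a limit, > 100000 nM, so compound 2 stands at the limit of > 100000 nM in this assay, at which 1 of the 2 values shown sits, and no number is known for it. Compound 3 `COc1ncnc2c1c(I)cn2[C@@H]1O[C@H](CO)[C@@H](O)[C@H]1O` is the unmeasured member and differs from compound 2 in one place: methoxy in place of methylamino on an aromatic carbon. Among the measured compounds shown here, the methoxy it gains is the group that compound 1 also carries, and compound 1 is the one compound here with a measured number. For the measured compounds named here, no step between measured compounds is available, so the size of the step from compound 2 to compound 3 can only be expected, not read off. The expectation is a large step towards stronger inhibition, an at least 50-fold lower number from compound 2 to compound 3 (1.69 log units; beyond the scatter), with considerable uncertainty. For compound 3 the estimate in this assay is 2000 nM, within a range from 200 nM to 30000 nM.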

Compound 3, half-maximal inhibitory concentration: > 20000 nM
Compound 3: a limit, no number; the forecaster's own chance of this, stated with the estimate: 25%; middle value at least 10-fold (1.00 log units) away from the limit.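

In this assay compound 3 gives a limit and not a number, so methoxy in place of methylamino does not lift the iodo compounds to a measured value: the limit of > 20000 nM in this assay, at which 1 of the 3 values shown sits.

Compound 2 also gives only a limit: the limit of > 100000 nM in this assay, at which 1 of the 3 values shown sits.

The step between these two limits cannot be read, which leaves the size of the methoxy for methylamino change unknown, whereas with methoxy held constant, iodo in place of thiophen-2-yl on an aromatic carbon gives an at least 280-fold higher number from compound 1 to compound 3 (2.45 log units; beyond the scatter).

Open, from the compounds shown here alone, is whether the number of compound 1 depends on thiophen-2-yl itself or would also hold with phenyl or an amine on that carbon. Also open, going by these compounds, is whether methylamino alongside thiophen-2-yl, or ethoxy in place of methoxy, would keep a measurable number in this assay.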